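This account rests on a few compounds, and the source may have more. Where it says the series, first, only, none or still open, it means among the compounds named here.

In a functional assay on Bel-7402 cells (Homo sapiens) for inhibition, read by MTT assay, with a stated time of 24 h, tested at 1 ug/mL (a lower number here means less inhibition of growth, a higher number more inhibition of growth at the concentration tested), three compounds have been tested so far. Compound 1 `CC(=O)SCCC(CCCCC(=O)O)SC(C)=O` gives 12.8%, and compound 2 `O=C(CCCCC1CCSS1)NO` gives 7.39%, two values within the usual scatter of each other. Compound 3 `O=C(CCCCC1CCSS1)Nc1ccccn1` is reported only as "not active" (no number reported), so it has no number that can be set directly against the other two.

Compound 4 `O=C(CCCCC1CCSS1)Nc1ccc(Cl)cn1` is built from compound 3 by one small change: chloro in place of hydrogen on an aromatic carbon, two atoms from the ring nitrogen and para to a large group (chloro in place of hydrogen on an aromatic carbon). Within the data shown here, no measured pair here shows what such a change does, so any forecast is uncertain. With compound 3 reported as "not active" (no number reported), a clear fall cannot be read from the data, and a slight rise in this assay is the likeliest direction, but no step beyond the scatter is expected. Compound 4 could also be reported without a number. For compound 4, the estimated growth inhibition is 6%, with an expected range of 0% to 18%.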

Compound 4, percent growth inhibition at one concentration: 7.44%
Estimate against measurement, compound 4: 1.4 percentage points below, and the stated range covers the measured number.
By their numbers in this assay, from the lowest: compounds 2, 4 and 1 (each within the scatter of the next).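

Among these compounds, compound 3 has no number, so no step to compound 4, which gives 7.44% here, can be read. No measurement shown offers an explanation for either result. From the compounds shown here alone, whether chloro in place of hydrogen on this ring changes growth inhibition at all remains open.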